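Carbamoyl in place of hydroxy: cytotoxicity notes

This account rests on a few compounds, and the source may have more. Where it says the series, first, only, none or still open, it means among the compounds named here.

Measured in a toxicity assay on MDCK cells (Canis lupus familiaris) for cytotoxicity, read by crystal violet staining, with a stated time of 48 h; a higher number here means that more compound is tolerated, a lower number that less compound is tolerated:
Compound 1 `CCc1ccc2[nH]c(=O)c(CN(Cc3ccc(F)cc3)Cc3ccc4ccccc4c3)cc2c1`: > 5000 nM (a limit)
Compound 2 `Cc1ccc2[nH]c(=O)c(CN(Cc3ccc(O)cc3)Cc3ccc(C(C)(C)C)cc3)cc2c1`: 4900 nM
Compound 3 `CCc1ccc2[nH]c(=O)c(CN(Cc3ccc(O)cc3)Cc3ccc(C(C)(C)C)cc3)cc2c1`: > 10000 nM (a limit)

Within the data shown here, compound 2 gives the only number in this assay, at 4900 nM. The other two entries are limits.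

Compound 4 `Cc1ccc2[nH]c(=O)c(CN(Cc3ccc(C(N)=O)cc3)Cc3ccc(C(C)(C)C)cc3)cc2c1` departs from compound 2 in one place: carbamoyl in place of hydroxy on an aromatic carbon. In words, 4-hydroxybenzyl gives way to 4-carbamoylbenzyl, with the change on an aromatic carbon para to a large group.

Among the measured compounds shown here, no measured step covers this exchange. For the measured compounds named here, the single step available is an at least 2.0-fold higher number from compound 2 to compound 3 (0.30 log units; that floor lies within the scatter). It concerns methyl in place of hydrogen on a saturated chain carbon, leaves the hydroxy group untouched, and bears on the present change only indirectly. Compound 1 differs from compound 2 in several places and gives only a limit.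

The expectation is for no change clearly beyond the scatter, with a slight lean towards more compound being tolerated. That lean rests on compound 3, which gives only the limit > 10000 nM. The expected size is a 1.4-fold higher number from compound 2 to compound 4 (0.15 log units; within the scatter), and a limit instead of a number would not be a surprise. For compound 4 the estimate is 7000 nM, with an expected range of 3000 nM to 15000 nM.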

Compound 4, half-maximal cytotoxic concentration: > 5000 nM
Compound 4 gave a limit, no number (the forecaster's own chance of this, stated with the estimate: 45%); the middle value is on the limit's open side.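

Carbamoyl in place of hydroxy on an aromatic carbon para to a large group is the only change shown at this position, and in this assay it reads as an at least 1.0-fold higher number from compound 2 to compound 4 (0.00 log units; that floor lies within the scatter). Within compounds 2 and 4, the hydroxy group is therefore not shown to be needed for the compound to be tolerated at the level of compound 2, and the larger carbamoyl group brings no measurable loss of tolerance at this position. The size of the step cannot be read, and whether it lies beyond the scatter stays unknown, because the entry for compound 4 is a limit and not a number: the limit of > 5000 nM in this assay, at which 2 of the 4 values shown sit.

A concentration range reaching past this limit would be needed to tell whether 4-carbamoylbenzyl and 4-hydroxybenzyl really differ in this assay. Also open, going by these compounds, is what a carboxylic acid, an amine or a methoxy group on the same aromatic carbon would give, and whether carbamoyl behaves the same way with ethyl in place of methyl on the shared core.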